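The source may hold more compounds than are shown below. What is called first, only, known or untested is meant among the compounds shown, and "the series" means these compounds.

Measured so far in a physicochemical assay for lipophilicity; a lower number here means a more polar compound, a higher number a more lipophilic compound:
- compound 1, `C[n+]1ccn(CCC#N)c1/C=N/O`: -3.3
- compound 2, `C[n+]1ccn(CCCCOC(=O)c2ccccc2O)c1/C=N/O`: -0.56
- compound 3, `C[n+]1ccn(COCCCCCl)c1/C=N/O`: -1.47

Compound 1 has the lowest of the three numbers in this assay. The nearest number belongs to compound 3, and that gap is beyond the scatter; the furthest belongs to compound 2, also well beyond the scatter. For the measured compounds named here, no pair among the three differs in only one place, so no single step between measured compounds can be read off.

Compound 4, `C[n+]1ccn(CCOCCCl)c1/C=N/O`, is not yet measured in this assay. It differs from compound 1 as follows: 2-chloroethoxy in place of cyano on a saturated chain carbon, two bonds along the chain from an aromatic nitrogen. The nearest measured relative by overall make-up is compound 3, which carries a chloroalkoxy chain on the same core and in this assay gives -1.47.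

For compound 4 a step upward from compound 1 is expected in this assay, of a size clearly beyond the scatter, estimated at a number 1.50 log units higher from compound 1 to compound 4 (beyond the scatter). The expected value for compound 4 is -1.8, with a range from -2.5 to -1.1, placed a little below compound 3 because the chain of compound 4 is one carbon shorter than the chain that gives compound 3 its -1.47.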

Compound 4, distribution coefficient: -2.32
Compound 4: middle estimate off by 0.52 log units, on the high side, within the range that was stated.
By their numbers in this assay, from the lowest: compound 1; then compound 4; then compound 3; then compound 2.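

Notes on the chain end of the series: in this assay, the exchange of cyano for 2-chloroethoxy on a saturated chain carbon, two bonds along the chain from an aromatic nitrogen, now gives the only single-place comparison available, and it reads a number 0.98 log units higher from compound 1 to compound 4 (beyond the scatter) on the shared core. For the compounds shown here, the position therefore responds to a change of group, which the earlier compounds could not show, since no two of them differed in only one place. The step comes with a move from 2 to 4 heavy atoms in the group, while the counts of hydrogen-bond donors and acceptors stay the same on both sides, and nothing measured accounts for its size.

The step carries the ether oxygen, the chlorine and the added chain carbons together, and a single pair cannot divide it among them. Still open, on these data alone, is how the same position reads with a plain ethoxy group lacking the chlorine, with a longer chloroalkoxy chain, or with an amine or a carboxylic acid at the chain end.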